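This account rests on a few compounds, and the source may have more. Where it says the series, first, only, none or still open, it means among the compounds named here.

The measured compounds in a functional assay on MDA-MB-231 cells (Homo sapiens) for antiproliferative activity, read by MTT assay, with a stated time of 72 h; a lower number here means a stronger inhibitor, a higher number a weaker inhibitor:

Compound 1 `O=C(Nc1cccc(-c2nc(-c3ccc(NC(=O)c4cccnc4)cc3Cl)no2)c1)c1ccccc1` gives 12800 nM.
Compound 2 `O=C(Nc1ccccc1)Nc1cccc(-c2nc(-c3ccc(NC(=O)c4cccnc4)cc3Cl)no2)c1` gives > 10000 nM, a limit of the assay rather than a number.
Compound 3 `NS(=O)(=O)c1ccc(NC(=O)Nc2cccc(-c3nc(-c4ccc(NC(=O)c5cccnc5)cc4Cl)no3)c2)cc1` gives > 10000 nM, likewise a limit of the assay.

Compound 3 therefore stands only at the limit, with no number of its own. Two of the three values sit at this limit (the limit of > 10000 nM in this assay, at which 2 of the 3 values shown sit), so the steps a step that the limit leaves unreadable from compound 1 to compound 2, a step that the limit leaves unreadable from compound 1 to compound 3 and a step that the two limits leave unreadable from compound 2 to compound 3 cannot be read in size. For the measured compounds named here, the only number in this assay is the weak value of compound 1.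

Compound 4 `Cc1ccc(NC(=O)Nc2cccc(-c3nc(-c4ccc(NC(=O)c5cccnc5)cc4Cl)no3)c2)cc1` differs from compound 3 in one place: methyl in place of sulfamoyl on an aromatic carbon. Going by the values given here, none of the measured steps can be read, so nothing shows how this change should move the value; the change from compound 2 to compound 3, the nearest comparison, is itself hidden by the limit. The expected step is a step that the limit leaves unreadable from compound 3 to compound 4. Compound 4 is estimated to give about 15000 nM in this assay, within 4000 nM to 50000 nM, and quite possibly only another limit.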

Compound 4, half-maximal inhibitory concentration: 3500 nM
Compound 4: the middle estimate sits 4.3-fold (0.63 log units) above what was measured; measured number outside the range, below it.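

In this assay, for the compounds shown here, the aromatic carbon para to a large group is the first place in this set where a change can be read: methyl in place of sulfamoyl gives an at least 2.8-fold lower number from compound 3 to compound 4 (0.45 log units; beyond the scatter), and methyl in place of hydrogen gives an at least 2.8-fold lower number from compound 2 to compound 4 (0.45 log units; beyond the scatter). Going by these compounds alone, changing phenyl on the carbonyl carbon to (4-methylphenyl)amino gives a 3.7-fold lower number from compound 1 to compound 4 (0.56 log units; beyond the scatter), so this change also separates compound 4 from the one earlier compound with a real number. With hydrogen or sulfamoyl on that carbon, compound 2 and compound 3 stay at a limit of the assay, so the group on this one carbon matters.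

Going by these compounds, whether ethyl, methoxy or chlorine on that carbon would give a lower number than methyl remains open. The steps among compound 1, compound 2 and compound 3 still cannot be read: the limit of > 10000 nM in this assay, at which 2 of the 4 values shown sit.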